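From a phenyl ether to a cyclohexylmethyl ether

The compounds below may be only part of what the source reports. "The series", "measured", "known", "first", "only" and "open" are said of these compounds alone.

Measured so far:
compound 1, `C[C@@H](NCc1ccc(Oc2ccccc2)cc1)C(N)=O`, 64 mg/kg
compound 2, `C[C@@H](NCc1ccc(CCc2ccccc2)cc1)C(N)=O`, 40.3 mg/kg

Both numbers come from a functional assay on the whole organism with Mus musculus as the target; on this read-out higher numbers stand for an effect only at larger amounts of compound and lower numbers for an effect already at smaller amounts. In this assay compound 1 gives 64 mg/kg, the higher of the two values, while compound 2 gives 40.3 mg/kg; the gap between them lies within the scatter, so the two compounds are not told apart by these data. For the measured compounds named here, no step between two measured compounds is available to guide the next change.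

Compound 3, `C[C@@H](NCc1ccc(OCC2CCCCC2)cc1)C(N)=O`, differs from compound 1 in one place: cyclohexylmethyl in place of phenyl on an oxygen on an aromatic ring. Going by the values given here, with only two measured compounds, which are within the scatter of each other, no direction is established for such a change. Compound 3 is therefore expected to land close to compound 1, with the step of a 1.3-fold lower number from compound 1 to compound 3 (0.11 log units; within the scatter) expected to stay within the scatter. The estimate for compound 3 in this assay is 50 mg/kg, with a range from 22 mg/kg to 110 mg/kg.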

Compound 3, dose for half-maximal effect: 131 mg/kg
Estimate against measurement, compound 3: 2.6-fold (0.42 log units) below, and the stated range ends below it.
By their numbers in this assay, from the lowest: compounds 2 and 1 (each within the scatter of the next); then compound 3.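

In this assay, the change to cyclohexylmethyl in place of phenyl on the oxygen on the aromatic ring gives a 2.0-fold higher number from compound 1 to compound 3 (0.31 log units; beyond the scatter), the only step shown and a modest one. It shows that the group at this place can shift the dose needed for an effect, which compounds 1 and 2 could not show, and that this change moves the number in the unfavourable direction, towards larger amounts of compound. Nothing available bears on why this happens.

The step swaps an aromatic ring for a non-aromatic one and adds a carbon in the same change, so the compounds shown do not separate these two differences. A benzyl group or a plain cyclohexyl group on that oxygen would tell them apart.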